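A Sulfonyl Swap on a Weakly Active Compound

This account rests on a few compounds, and the source may have more. Where it says the series, first, only, none or still open, it means among the compounds named here.

- compound 1 `Cc1ccc(S(=O)(=O)Oc2ccccc2/C=C(\C#N)C(=O)Nc2nnc(C)s2)cc1`: 78%
- compound 2 `N#C/C(=C\c1cccc(NS(=O)(=O)c2ccc(F)cc2)c1)C(=O)Nc1nnc(-c2cccs2)s1`: "not active" (no number reported)
- compound 3 `COc1ccc(Cc2nnc(NC(=O)/C(C#N)=C/c3ccccc3OS(=O)(=O)c3ccc(C)cc3)s2)cc1`: 25%

All three compounds were tested in a functional assay on HL-60 cells (Homo sapiens) for inhibition, read by CCK-8 assay, with a stated time of 48 h, tested at 20 uM; a higher number here means more inhibition of growth at the concentration tested, a lower number less inhibition of growth. Compound 3, at 25%, holds the lower of the two numbers available, while compound 2 is reported only as "not active" (no number reported) and offers no number for comparison.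

The next compound, compound 4 `COc1ccc(Cc2nnc(NC(=O)/C(C#N)=C/c3ccccc3OS(=O)(=O)c3ccccc3[N+](=O)[O-])s2)cc1`, differs from compound 3 in one place: 2-nitrophenyl in place of 4-methylphenyl on a sulfonyl sulfur. In words, 2-nitrophenyl stands in place of 4-methylphenyl on a sulfonyl sulfur.

For the measured compounds named here, only one measured step is available, and it shows a number a number 53 percentage points lower from compound 1 to compound 3 (beyond the scatter). That step is large and beyond the scatter, but it involves 4-methoxyphenyl in place of hydrogen on a saturated chain carbon bound to an aromatic carbon. It therefore says nothing direct about a change on the sulfonyl sulfur. Compound 2 differs in several places and has no number, so it cannot size this change either.

With no measured guide, no shift beyond the scatter is expected, and the estimated step is a number 2 percentage points higher from compound 3 to compound 4 (within the scatter) in this assay. Going by the values given here, still, the size of the one known step argues for caution. For compound 4 the expected value is 27%, with an estimated range from 8% to 52% in this assay.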

Compound 4, percent growth inhibition at one concentration: 25%
Compound 4: middle estimate off by 2 percentage points, on the high side; measured number inside the range.
By their numbers in this assay, from the lowest: compounds 3 and 4 (each within the scatter of the next); then compound 1.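

In this assay, for the compounds shown here, the sulfonyl sulfur is now probed directly for the first time, and replacing 4-methylphenyl with 2-nitrophenyl gives no change at the digits printed from compound 3 to compound 4 (within the scatter). The entering group has more heavy atoms than the one it replaces and brings hydrogen-bond acceptors that 4-methylphenyl lacks, yet growth inhibition at the tested concentration stays within the scatter. The earlier step, a number 53 percentage points lower from compound 1 to compound 3 (beyond the scatter), belongs to a different place, so this pair gives the first sign that, at least with the 4-methoxyphenyl group present, this particular swap on the sulfonyl sulfur leaves the read-out unmoved, although one pair sets no rule for the position.

On these data alone, it remains open whether the same swap would be equally quiet on compound 1, which lacks the 4-methoxyphenyl group. As far as these compounds go, it is also open whether a phenyl ring carrying an amine or a carboxylic acid, or a butyl chain in place of the ring, would leave the read-out just as unmoved on the sulfonyl sulfur. No independent measurement is available to explain this result.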